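A few compounds are considered here, and "the series" means these few. Any claim that something is new, unique, unknown or untested is made for them only; others in the source may bear on it.

Measured compounds:
Compound 1, `COc1cc(CN(C)C(=O)c2c(OCCCC3CCN(C(=O)OC(C)(C)C)CC3)c3cnccc3n(C)c2=O)cc(OC)c1`: 1600 nM
Compound 2, `CN(Cc1cc(C(F)(F)F)cc(C(F)(F)F)c1)C(=O)c1c(OCCCC2CCCCC2)c2ccccc2n(C)c1=O`: 480 nM

In an assay on cells for inhibition of phosphatidylcholine:ceramide cholinephosphotransferase 2 (Homo sapiens), read by mass spectrometry, with stated times of 60 min and 30 min (a lower number here means a stronger inhibitor, a higher number a weaker inhibitor), compound 2 gives the lower of the two numbers, and the number of compound 1 lies beyond the scatter above it. Compound 3, `CN(Cc1cc(C(F)(F)F)cc(C(F)(F)F)c1)C(=O)c1c(OCCCC(F)(F)F)c2ccccc2n(C)c1=O`, differs from compound 2 in one place: trifluoromethyl in place of cyclohexyl on a saturated chain carbon, three bonds along the chain from an oxygen on an aromatic ring. For the measured compounds named here, no measured pair shows this change, so its effect is uncertain. A modest weakening is expected, the step of a 2.5-fold higher number from compound 2 to compound 3 (0.40 log units; beyond the scatter) being only somewhat beyond the scatter. Compound 3 is therefore estimated at 1200 nM in this assay, with a range from 400 nM to 4000 nM.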

Compound 3, half-maximal inhibitory concentration: 120 nM
Compound 3: the middle estimate sits 10-fold (1.00 log units) above what was measured; measured number below the stated range.
By their numbers in this assay, from the lowest: compound 3; then compound 2; then compound 1.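

In this assay, trifluoromethyl in place of cyclohexyl at the end of the chain gives a 4.0-fold lower number from compound 2 to compound 3 (0.60 log units; beyond the scatter) and so improves the number. The ring of compound 2 is therefore not required at this position, and the 4,4,4-trifluorobutyl group, with fewer heavy atoms, does better than 3-cyclohexylpropyl. No measurement shown here explains this gain. Still open, on these data alone, is how a plain butyl chain, a longer chain or an amine at the chain end would compare. As far as these compounds go, whether the same change helps on the core of compound 1 is also open.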